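Moving from methyl to tert-butyl on the imine nitrogen

The source may hold more compounds than are shown below. What is called first, only, known or untested is meant among the compounds shown, and "the series" means these compounds.

The series shares a core that is carried by compound 1 `COc1ccc(C/N=c2\c(O)c(O)\c2=N/C(C)(C)C)cc1`, compound 2 `CC(C)(C)/N=c1\c(O)c(O)\c1=N/Cc1ccc(Cl)cc1` and compound 3 `C/N=c1\c(O)c(O)\c1=N/Cc1ccc(C#N)cc1`. Going by the values given here, in a functional assay for inhibition, with Rattus norvegicus as the target (a higher number here means a weaker inhibitor, a lower number a stronger inhibitor), compound 1 gives 4800 nM and compound 2 gives 1700 nM, so the one measured step, a 2.8-fold lower number from compound 1 to compound 2 (0.45 log units; beyond the scatter), is modest. For compound 3 this assay reports only a limit, > 30000 nM. Compound 3 therefore stands apart from the two numbered compounds: the limit of > 30000 nM in this assay, at which 1 of the 3 values shown sits, and it is the only one of the three at that limit, whereas compounds 1 and 2 both give numbers.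

The next compound, compound 4 `CC(C)(C)/N=c1\c(O)c(O)\c1=N/Cc1ccc(C#N)cc1`, differs from compound 3 by tert-butyl in place of methyl on a double-bonded nitrogen. Among the compounds with values here, no measured step bears on this change: the only measured step concerns a substituent on the aromatic ring, not the group on the double-bonded nitrogen. What can be said is that compound 1 and compound 2, which both carry tert-butyl at that position, give numbers in this assay, while compound 3, which carries methyl, gives only a limit. On that basis compound 4 is expected to return a number rather than a limit, though the nitrile it shares with compound 3 is otherwise untested with tert-butyl. The expected step is an at least 5.0-fold lower number from compound 3 to compound 4 (0.69 log units; beyond the scatter). Compound 4 is therefore estimated at 6000 nM, with a range from 1500 nM to 30000 nM.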

Compound 4, half-maximal inhibitory concentration: 270 nM
Beside the measured number, compound 4's estimate is 22-fold (1.35 log units) above it, outside the stated range (below it).
By their numbers in this assay, from the lowest: compound 4; then compound 2; then compound 1. At a limit, above all of these: compound 3.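

Tert-butyl in place of methyl on a double-bonded nitrogen gives an at least 110-fold lower number from compound 3 to compound 4 (2.04 log units; beyond the scatter) with the nitrile left unchanged, the first reading of this position, and it shows that this group alone can carry a large change in this assay. With tert-butyl held in place, cyano on the aromatic carbon also gives a lower number than the two earlier substituents, with a 6.3-fold lower number from compound 2 to compound 4 (0.80 log units; beyond the scatter) on replacing chloro and an 18-fold lower number from compound 1 to compound 4 (1.25 log units; beyond the scatter) on replacing methoxy, and so compound 4 is the strongest inhibitor of the four. Compound 3 has only a limit, so the step from methyl to tert-butyl is a bound and not an exact size: the limit of > 30000 nM in this assay, at which 1 of the 4 values shown sits.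

The compounds shown do not tell whether ethyl or isopropyl on the double-bonded nitrogen would give part of this change, whether a ring such as cyclohexyl could take the place of tert-butyl, or whether the same change would hold with chloro or methoxy on the aromatic carbon. They also leave open how trifluoromethyl or a carboxylic acid at that aromatic carbon would compare with cyano.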